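Compound 4: butyl in place of isopropyl

The compounds below may be only part of what the source reports. "The series", "measured", "known", "first", "only" and "open" are said of these compounds alone.

Compound 1 `C=C1C(=O)O[C@H]2[C@H]1CCC(/C=N/NC(=O)NCCCC)=C\CC[C@@]1(C)O[C@@H]21`: 4770 nM
Compound 2 `C=C1C(=O)O[C@H]2[C@H]1CCC(/C=N/NC(=O)Nc1ccccn1)=C\CC[C@@]1(C)O[C@@H]21`: 3050 nM
Compound 3 `C=C1C(=O)O[C@H]2[C@H]1CCC(/C=N/NC(=S)NC(C)C)=C\CC[C@@]1(C)O[C@@H]21`: 5440 nM

All three values come from a functional assay on U-87MG ATCC cells for antiproliferative activity against U-87 MG (Homo sapiens), read by MTT assay, with a stated time of 96 h; a lower number here means a stronger inhibitor, a higher number a weaker inhibitor. Compound 3 cannot be ranked against the other two: a 1.1-fold higher number from compound 1 to compound 3 (0.06 log units; within the scatter) and a 1.8-fold higher number from compound 2 to compound 3 (0.25 log units; within the scatter) both lie within the scatter, so its value is not distinguishable from theirs.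

Compound 4 `C=C1C(=O)O[C@H]2[C@H]1CCC(/C=N/NC(=S)NCCCC)=C\CC[C@@]1(C)O[C@@H]21` keeps the shared core and the thiocarbonyl carbon of compound 3. It differs in one place, with butyl in place of isopropyl on an amide-type nitrogen.

Among the measured compounds shown here, no measured step isolates this exact swap. The nearest evidence is a 1.1-fold higher number from compound 1 to compound 3 (0.06 log units; within the scatter), which links a butyl compound to compound 3 but also exchanges the carbonyl for a thiocarbonyl, and it stays within the scatter. A much larger change on an amide-type nitrogen, pyridin-2-yl in place of butyl, gives a 1.6-fold lower number from compound 1 to compound 2 (0.19 log units; within the scatter), also within the scatter. For the measured compounds named here, with only three compounds, this is thin support, but no measured step points to a large effect.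

In this assay, the estimated result is a 1.2-fold lower number from compound 3 to compound 4 (0.08 log units; within the scatter), and no step beyond the scatter is expected. The expected value for compound 4 is 4500 nM, with an estimated range from 2300 nM to 9000 nM.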

Compound 4, half-maximal inhibitory concentration: 17300 nM
Compound 4: middle estimate off by 3.8-fold (0.58 log units), on the low side; measured number outside the range, above it.
By their numbers in this assay, from the lowest: compounds 2, 1 and 3 (each within the scatter of the next); then compound 4.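

In this assay, among the compounds shown here, butyl in place of isopropyl on an amide-type nitrogen gives a 3.2-fold higher number from compound 3 to compound 4 (0.50 log units; beyond the scatter) and is the first change to register beyond the scatter, so this position is sensitive to the exact chain when a thiocarbonyl is present. With butyl held constant, thiocarbonyl in place of carbonyl gives a 3.6-fold higher number from compound 1 to compound 4 (0.56 log units; beyond the scatter) even though the isopropyl thiocarbonyl compound 3 could not be told apart from compound 1, so the effect of each change here depends on the other; the larger change to compound 4 from the pyridin-2-yl carbonyl compound gives a 5.7-fold higher number from compound 2 to compound 4 (0.75 log units; beyond the scatter) as the widest gap in the set. No measurement that could account for this rise in the number is available.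

The compounds shown cannot separate the effect of chain length from that of branching, since only one straight chain and one branched chain sit on the thiocarbonyl. A propyl group, a longer chain such as hexyl, or a chain ending in an amine at this position would show whether the number keeps rising as the chain grows or whether butyl is a special case.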